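A few compounds are considered here, and "the series" means these few. Any claim that something is new, unique, unknown or untested is made for them only; others in the source may bear on it.

Measured in a functional assay on MCF7 cells (Homo sapiens) for antiproliferative activity, read by sulforhodamine B assay, with a stated time of 72 h; on this read-out higher numbers stand for weaker inhibition and lower numbers for stronger inhibition:
- compound 1 `CCCCS(=O)(=O)Nc1cc(-c2ccc3ncnc(NCCN(C)C)c3c2)cnc1OC`: 3240 nM
- compound 2 `COc1ncc(-c2ccc3ncnc(NCCN(C)C)c3c2)cc1NS(=O)(=O)c1ccc(F)cc1`: 1230 nM

The two compounds share a core and differ only in the group on the sulfonyl sulfur. Compound 2, with its 4-fluorophenyl group, holds the lower of the two numbers at 1230 nM, and compound 1, with its butyl group, stands at 3240 nM.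

The next compound is compound 3 `COc1ncc(-c2ccc3ncnc(NCCN(C)C)c3c2)cc1NS(=O)(=O)c1ccc(F)cc1F`, in which 4-fluorophenyl becomes 2,4-difluorophenyl: fluoro in place of hydrogen on an aromatic carbon. Within the data shown here, only one measured step bears on this change, a 2.6-fold lower number from compound 1 to compound 2 (0.42 log units; beyond the scatter), a modest move in which the whole butyl group gave way to 4-fluorophenyl. Among the measured compounds shown here, no measured pair shows what a fluoro in place of hydrogen does on this ring. The present change is much smaller than that replacement, so a smaller step is expected, most likely none beyond the scatter in this assay, with only a slight lean towards a lower number. The estimated step is a 1.3-fold lower number from compound 2 to compound 3 (0.11 log units; within the scatter). For compound 3 the expected value is 950 nM, within an estimated range of 380 nM to 2400 nM.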

Compound 3, half-maximal inhibitory concentration: 1020 nM
Estimate against measurement, compound 3: 1.1-fold (0.03 log units) below; measured number inside the range.
By their numbers in this assay, from the lowest: compounds 3 and 2 (each within the scatter of the next); then compound 1.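

In this assay, the added fluoro, ortho to a large group and meta to a fluoro group on the aromatic ring, gives a 1.2-fold lower number from compound 2 to compound 3 (0.08 log units; within the scatter), so the change from 4-fluorophenyl to 2,4-difluorophenyl cannot be told apart from repeat measurement, and this position on the ring accepts a fluoro in place of hydrogen with no readable change in the number. What the earlier pair showed for one aromatic group now holds for a second: 2,4-difluorophenyl in place of butyl on the sulfonyl sulfur gives a 3.2-fold lower number from compound 1 to compound 3 (0.50 log units; beyond the scatter), a modest step of the same standing as a 2.6-fold lower number from compound 1 to compound 2 (0.42 log units; beyond the scatter), and both aromatic groups sit apart from butyl beyond the scatter. Nothing in the data given here explains either the flat step or the two modest ones.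

The compounds shown leave open whether a larger group at this ring position, such as methoxy or trifluoromethyl, would move the number beyond the scatter, since a fluoro is the only replacement of hydrogen seen there. They also leave open what a chloro on the ring, or a shorter chain such as methyl on the sulfonyl sulfur, would do in this series.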